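Taking the methyl group off compound 2

The source may report more compounds than this note shows. Statements on the series, on what has been measured and on what is new or still open speak of the compounds shown alone.

- Compound 1 `C[C@@]1(c2cc(NC(=O)c3cnc(OCF)cn3)ccc2F)C=C(CF)OC(N)=N1` gives 52%
- Compound 2 `Cc1cc(C#N)cnc1C(=O)Nc1ccc(F)c([C@]2(C)C=C(CF)OC(N)=N2)c1` gives 34%
- Compound 3 `C[C@@]1(c2cc(NC(=O)c3ncc(OCF)nc3N)ccc2F)C=C(CF)OC(N)=N1` gives 35%

These values come from an ADME assay on microsomes from liver (Rattus norvegicus, strain Crj;CD(SD)) for metabolic stability, read by LC-MS, using NADPH, with a stated time of 30 min, tested at 0.1 uM; a higher number here means that more of the compound is left, a lower number that less of the compound is left. Compound 2 at 34% sits level with compound 3 (a number 1 percentage points higher from compound 2 to compound 3 (within the scatter)). The remaining gap is clear (a number 18 percentage points lower from compound 1 to compound 2 (beyond the scatter)).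

Compound 4 `C[C@@]1(c2cc(NC(=O)c3ccc(C#N)cn3)ccc2F)C=C(CF)OC(N)=N1` differs from compound 2 by one change (hydrogen in place of methyl on an aromatic carbon), which reads hydrogen in place of methyl on an aromatic carbon. For the measured compounds named here, no measured step makes exactly this change. The closest is a number 17 percentage points lower from compound 1 to compound 3 (beyond the scatter), where amino took the place of hydrogen on an aromatic carbon. Gaining a group went with less compound left there, but that group is a different one on a different ring, so it is only a weak guide. The step of a number 18 percentage points lower from compound 1 to compound 2 (beyond the scatter) swaps the whole group on the carbonyl carbon and says less still. Read in reverse, these steps point to a small upward step, not clearly beyond the scatter. The expected step is a number 9 percentage points higher from compound 2 to compound 4 (within the scatter) in this estimate. For compound 4 the estimated value is 43% with an expected range from 28% to 58%.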

Compound 4, percent of the compound remaining: 55%
Estimate against measurement, compound 4: 12 percentage points below, and the stated range covers the measured number.
By their numbers in this assay, from the lowest: compounds 2 and 3 (each within the scatter of the next); then compounds 1 and 4 (each within the scatter of the next).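

In this assay, the single methyl ortho to a large group turns out to matter by itself: going from 5-cyano-3-methylpyridin-2-yl to 5-cyanopyridin-2-yl gives a number 21 percentage points higher from compound 2 to compound 4 (beyond the scatter). On the carbonyl carbon, 5-cyanopyridin-2-yl in place of 3-amino-5-(fluoromethoxy)pyrazin-2-yl gives a number 20 percentage points higher from compound 3 to compound 4 (beyond the scatter), whereas in place of 5-(fluoromethoxy)pyrazin-2-yl it gives a number 3 percentage points higher from compound 1 to compound 4 (within the scatter), so these last two groups cannot be told apart in this measurement. Nothing available here explains why removing the methyl goes with more compound being left.

The compounds shown leave open how a methoxy group, a chlorine atom or an ethyl group would read on this same aromatic carbon. From the compounds shown here alone, the methyl step also rests on a single pair of compounds, so whether it holds with other groups elsewhere on the ring remains unknown.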